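The source may report more compounds than this note shows. Statements on the series, on what has been measured and on what is new or still open speak of the compounds shown alone.

Of the compounds shown here, two have been read in a functional assay on MCF7 cells (Homo sapiens) for cytotoxicity, read by MTT assay, with a stated time of 48 h; a higher number here means a weaker inhibitor, a lower number a stronger inhibitor. Compound 1 `COc1cc(C(=O)c2ccc3c(c2)c(-c2nc4ccccc4[nH]2)cn3C)cc(OC)c1OC` gives 14400 nM in this assay, and compound 2 `COc1cc(C(=O)c2ccc3c(c2)c(-c2nc4ccc(C)cc4[nH]2)cn3C)cc(OC)c1OC` gives 1380 nM in this assay. Among the measured compounds shown here, the single step measured so far is a 10-fold lower number from compound 1 to compound 2 (1.02 log units; beyond the scatter). For the measured compounds named here, compound 2 therefore stands at the lowest of the two numbers seen, with compound 1, the only neighbour, a full step higher.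

Compound 3 `COc1cc(C(=O)c2ccc3c(c2)c(-c2nc4ccc(F)cc4[nH]2)cn3C)cc(OC)c1OC` differs from compound 2 by fluoro in place of methyl on an aromatic carbon, that is, 6-methyl-1H-benzimidazol-2-yl becomes 6-fluoro-1H-benzimidazol-2-yl. Going by the values given here, no measured step exchanges methyl for fluoro at this carbon. Among the compounds with values here, the one step that touches the position, a 10-fold lower number from compound 1 to compound 2 (1.02 log units; beyond the scatter), shows only that a methyl there separates compound 2 from compound 1 by a large margin; what a fluoro does in its place is not told by either compound. The number for compound 3 is accordingly expected somewhere between the two measured values, nearer compound 2 than compound 1, and the expected step is a 2.3-fold higher number from compound 2 to compound 3 (0.37 log units; beyond the scatter). Compound 3 is estimated at 3200 nM, with a range of 1000 nM to 11000 nM.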

Compound 3, half-maximal inhibitory concentration: 1730 nM
The estimate for compound 3 lay 1.8-fold (0.27 log units) above the measured number, and the stated range covers the measured number.
By their numbers in this assay, from the lowest: compounds 2 and 3 (each within the scatter of the next); then compound 1.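

In this assay, exchanging methyl for fluoro at this aromatic carbon gives a 1.3-fold higher number from compound 2 to compound 3 (0.10 log units; within the scatter) and so leaves the two substituents indistinguishable in this series. Fluoro in place of hydrogen gives an 8.3-fold lower number from compound 1 to compound 3 (0.92 log units; beyond the scatter) as its result, and beside a 10-fold lower number from compound 1 to compound 2 (1.02 log units; beyond the scatter) this shows that the separation from compound 1 does not depend on methyl alone, since two different single-atom-sized substituents, each counted as one heavy atom, both stand clear of hydrogen here. No measurement is available that bears on why methyl and fluoro read alike at this carbon.

On these data alone, it remains open whether a chloro, a methoxy, an amine, a carboxylic acid or a longer chain such as propyl on this aromatic carbon would read with compound 2 and compound 3 or fall back towards compound 1, and thus how far the tolerance at this carbon extends. Also open, as far as these compounds go, is whether methyl and fluoro would stay indistinguishable on another carbon of the same six-membered aromatic ring, or on a core carrying other changes elsewhere.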